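This account rests on a few compounds, and the source may have more. Where it says the series, first, only, none or still open, it means among the compounds named here.

Measured compounds in a functional assay on MGC-803 cells (Homo sapiens) for inhibition, read by MTT assay, with a stated time of 48 h; on this read-out lower numbers stand for stronger inhibition and higher numbers for weaker inhibition:
Compound 1, `COc1ccc(CN(c2cc(OC)c(OC)c(OC)c2)S(=O)(=O)c2ccccc2)cc1`, gives > 50000 nM, which is a limit of the assay rather than a number.
Compound 2, `COc1ccc(CN(c2cc(OC)c(OC)c(OC)c2)S(=O)(=O)c2ccc(C(C)(C)C)cc2)cc1`, gives 10300 nM.
Compound 3, `COc1cc(N(Cc2ccc(Cl)cc2)S(=O)(=O)c2ccc(C)cc2)cc(OC)c1OC`, gives 1720 nM.

Compound 3 thus gives the lower of the two numbers, the other belonging to compound 2. Going by the values given here, the only measured step, an at least 4.8-fold lower number from compound 1 to compound 2 (0.68 log units; beyond the scatter), changes a group on the sulfonyl-bearing ring, a different place from the change now considered. Compound 4, `COc1cc(N(Cc2csc3ccc(Cl)cc23)S(=O)(=O)c2ccc(C)cc2)cc(OC)c1OC`, differs from compound 3 by 5-chloro-1-benzothiophen-3-yl in place of 4-chlorophenyl on a saturated chain carbon bound to a sulfonamide nitrogen. Among the compounds with values here, no measured step covers this change, so the direction is open, and a step of a 1.1-fold lower number from compound 3 to compound 4 (0.06 log units; within the scatter) in this assay is expected, within the scatter. Compound 4 is estimated at 1500 nM, ranging from 400 nM to 6000 nM.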

Compound 4, half-maximal inhibitory concentration: 3450 nM
Compound 4: middle estimate off by 2.3-fold (0.36 log units), on the low side; the measured number falls inside the stated range.
By their numbers in this assay, from the lowest: compounds 3 and 4 (each within the scatter of the next); then compound 2. At a limit, above all of these: compound 1.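

Going by these compounds alone, the only earlier step changed the sulfonyl-bearing ring, so this is the first view of the group on a saturated chain carbon bound to a sulfonamide nitrogen. In this assay the change gives a 2.0-fold higher number from compound 3 to compound 4 (0.30 log units; within the scatter) and so this place accepts 5-chloro-1-benzothiophen-3-yl, with its added five-membered aromatic ring, in place of 4-chlorophenyl. Nothing measured here offers a reason for this result. Still open, going by these compounds, is whether this place also accepts a ring carrying an amine or a carboxylic acid instead of the chlorine.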